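A few compounds are considered here, and "the series" means these few. Any claim that something is new, unique, unknown or untested is made for them only; others in the source may bear on it.

Working notes on the series.

Of the compounds shown here, three of the shared core have been measured in a functional assay on HCT-116 cells (Homo sapiens) for inhibition, read by MTT assay, with a stated time of 24 h, tested at 10 uM; on this read-out higher numbers stand for more inhibition of growth at the one concentration tested and lower numbers for less inhibition of growth. Compound 1 `CS(=O)(=O)c1ccc(-c2cnc3[nH]cc(-c4nnc(-c5ccncc5)o4)c(=O)c3c2)cc1` gives 7.83% in this assay, compound 2 `Cc1ccc(-c2nnc(-c3c[nH]c4ncc(-c5ccc(S(C)(=O)=O)cc5)cc4c3=O)o2)cc1` gives 24.4%, and compound 3 `CS(=O)(=O)c1ccc(-c2cnc3[nH]cc(-c4nnc(-c5cccnc5)o4)c(=O)c3c2)cc1` gives 14.7%. On these numbers compound 3 stands second highest of the three, with a number 6.9 percentage points higher from compound 1 to compound 3 (within the scatter) and a number 9.7 percentage points lower from compound 2 to compound 3 (within the scatter), both within the scatter, so no order among the three is secure.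

Compound 4 `Cc1cccc(-c2nnc(-c3c[nH]c4ncc(-c5ccc(S(C)(=O)=O)cc5)cc4c3=O)o2)c1` differs from compound 3 in one place: 3-methylphenyl in place of pyridin-3-yl on an aromatic carbon. Among the measured compounds shown here, two measured steps bear on this. The step of a number 16.6 percentage points higher from compound 1 to compound 2 (beyond the scatter) shows that a methylphenyl group in place of a pyridyl group at this position gave a modest rise beyond the scatter, and the step of a number 9.7 percentage points lower from compound 2 to compound 3 (within the scatter) shows that the reverse kind of change gave a smaller drop within the scatter. Taken together, a modest rise in this assay is expected for compound 4, with a number 8.3 percentage points higher from compound 3 to compound 4 (within the scatter) as the estimated step. Compound 4 is therefore expected to give about 23% in this assay, within a range of 10% to 36%.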

Compound 4, percent growth inhibition at one concentration: 25.2%
Beside the measured number, compound 4's estimate is 2.2 percentage points below it; the range from low to high includes it.
By their numbers in this assay, from the lowest: compounds 1, 3, 2 and 4 (each within the scatter of the next, the first and the last beyond it).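

In this assay the 3-methylphenyl group in place of pyridin-3-yl gives a step beyond the scatter, a number 10.5 percentage points higher from compound 3 to compound 4 (beyond the scatter), and the same group in place of pyridin-4-yl gives another, a number 17.4 percentage points higher from compound 1 to compound 4 (beyond the scatter), so compound 4 separates from both pyridyl compounds, while compound 2 separates only from compound 1. Changing 4-methylphenyl to 3-methylphenyl gives a number 0.8 percentage points higher from compound 2 to compound 4 (within the scatter), so the site of the methyl on this ring makes no readable difference between these two compounds. Nothing measured here explains these steps.

Open is whether the methyl itself matters, since an unsubstituted phenyl, a 2-methylphenyl or a methoxy-bearing phenyl does not appear among these compounds. Also open, going by these compounds, is how an amine or a carboxylic acid on this phenyl ring would read.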